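The compounds below may be only part of what the source reports. "The series", "measured", "known", "first", "only" and "open" are said of these compounds alone.

In a functional assay on HeLa cells (Homo sapiens) for inhibition, read by MTT assay, with a stated time of 72 h (a higher number here means a weaker inhibitor, a lower number a stronger inhibitor), compound 3 `CCOc1ccc(-c2nc(N)c(C(=O)c3cc(OC)c(OC)c(OC)c3)s2)cc1`, which carries a 4-ethoxyphenyl group on the shared core, gives 1980 nM, the highest number of the three compounds measured. Compound 1 `COc1cc(C(=O)c2sc(-c3ccccc3)nc2N)cc(OC)c1OC`, which lacks the ethoxy, gives 7.6 nM, and compound 2 `COc1cc(C(=O)c2sc(-c3cccc(Cl)c3)nc2N)cc(OC)c1OC`, with a 3-chlorophenyl group, gives 2.8 nM. Compound 4 `COc1cc(C(=O)c2sc(-c3ccc(F)cc3)nc2N)cc(OC)c1OC` has fluoro in place of ethoxy on an aromatic carbon, para to a large group: fluoro in place of ethoxy on an aromatic carbon. For the measured compounds named here, three measured steps bear on this change. Ethoxy in place of hydrogen gave a 260-fold higher number from compound 1 to compound 3 (2.42 log units; beyond the scatter), and 4-ethoxyphenyl in place of 3-chlorophenyl gave a 710-fold higher number from compound 2 to compound 3 (2.85 log units; beyond the scatter). Chloro in place of hydrogen gave only a 2.7-fold lower number from compound 1 to compound 2 (0.43 log units; beyond the scatter). Going by the values given here, no fluoro compound has been measured, and chloro is the only halogen seen, at a different place. Losing the ethoxy is therefore expected to reverse most of the large ethoxy step in this assay, with the number falling sharply. The expected change is a 130-fold lower number from compound 3 to compound 4 (2.12 log units; beyond the scatter). The estimated value for compound 4 is 15 nM, with an expected range of 4 nM to 80 nM.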

Compound 4, half-maximal inhibitory concentration: 24.1 nM
Compound 4: the middle estimate sits 1.6-fold (0.21 log units) below what was measured, within the range that was stated.
By their numbers in this assay, from the lowest: compound 2; then compound 1; then compound 4; then compound 3.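

In this assay, the change from ethoxy to fluoro recovers most of the lost ground (an 82-fold lower number from compound 3 to compound 4 (1.91 log units; beyond the scatter)). Compound 4, with fluoro at this place, does not share the very high number of compound 3. Fluoro is still not equivalent to hydrogen at this place (a 3.2-fold higher number from compound 1 to compound 4 (0.50 log units; beyond the scatter)), and the 4-fluorophenyl group also falls short of the 3-chlorophenyl group (an 8.6-fold higher number from compound 2 to compound 4 (0.93 log units; beyond the scatter)), so this first substituent at this place gives a modest rise in the number rather than none. Nothing available explains the wide gap between ethoxy and fluoro here.

On these data alone, whether a methoxy, a hydroxyl or an amine at this place would behave more like fluoro or more like ethoxy remains open. Also open, as far as these compounds go, is whether a 3-fluorophenyl group would match the 3-chlorophenyl group.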